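From Ethyl to Acetoxy: An Estimate for Compound 3

The compounds below may be only part of what the source reports. "The series", "measured", "known", "first", "only" and "open" are said of these compounds alone.

Of the compounds shown here, two sharing one core have so far been tested in an ADME assay on HepG2 2.2.15 cells (Homo sapiens) for cytotoxicity (on this read-out lower numbers stand for higher toxicity in this test and higher numbers for lower toxicity in this test), and their numbers lie within the usual scatter of each other. Compound 1 `CCC(=O)OCCc1c(-c2ccccc2Cl)c2cc(Cl)ccc2[nH]c1=O` gives 95000 nM there and compound 2 `CCCC(=O)OCCc1c(-c2ccccc2Cl)c2cc(Cl)ccc2[nH]c1=O` gives 52000 nM there. Compound 3 `CC(=O)OCC(=O)OCCc1c(-c2ccccc2Cl)c2cc(Cl)ccc2[nH]c1=O` has not been measured yet. It carries acetoxy in place of ethyl on a saturated chain carbon bound to a carbonyl carbon. For the measured compounds named here, only one measured step bears on this, and it is a smaller edit, methyl in place of hydrogen on the chain: a 1.8-fold lower number from compound 1 to compound 2 (0.26 log units; within the scatter) stays within the scatter. Going by the values given here, no tested compound carries acetoxy, so the data point in no direction. The estimated change is a 1.3-fold higher number from compound 2 to compound 3 (0.13 log units; within the scatter) and no shift beyond the scatter is expected. Compound 3 is estimated at 70000 nM within an expected range from 30000 nM to 160000 nM for now.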

Compound 3, half-maximal cytotoxic concentration: 100000 nM
Compound 3: middle estimate off by 1.4-fold (0.15 log units), on the low side; the range from low to high includes it.
By their numbers in this assay, from the lowest: compounds 2, 1 and 3 (each within the scatter of the next).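

Putting acetoxy in place of ethyl on a saturated chain carbon bound to a carbonyl carbon is a much larger edit than adding one methyl, since it brings in oxygen atoms and hydrogen-bond acceptors that ethyl lacks, yet this assay shows a 1.9-fold higher number from compound 2 to compound 3 (0.28 log units; within the scatter). Acetoxy in place of methyl at the same carbon gives a 1.1-fold higher number from compound 1 to compound 3 (0.02 log units; within the scatter), so all three compounds lie within the scatter of one another, and this position has now taken both a small and a larger change without a clear shift in the read-out. Nothing available explains why these numbers stay so close.

Still open, as far as these compounds go, is whether an amine or a carboxylic acid at this carbon would move the number beyond the scatter. A much longer chain there poses the same question, and so does any change to the shared core.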